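The source may report more compounds than this note shows. Statements on the series, on what has been measured and on what is new or still open speak of the compounds shown alone.

Of the compounds shown here, two built on the same core have been tested in a functional assay on SMMC-7721 cells (Homo sapiens) for antiproliferative activity, read by MTT assay, with a stated time of 48 h; on this read-out lower numbers stand for stronger inhibition and higher numbers for weaker inhibition. Compound 1 `COc1cccc(C(=O)c2ccc(OC)c(OC(=O)CCC(=O)OC[C@@H]3C=C[C@H](n4cc(C)c(=O)[nH]c4=O)O3)c2)c1` gives 820 nM in this assay. Compound 2 `COc1ccc(C(=O)c2ccc(F)cc2)cc1OCC(=O)OC[C@@H]1C=C[C@H](n2cc(C)c(=O)[nH]c2=O)O1` gives 40300 nM in this assay, the highest of the two numbers, and its gap to compound 1 lies beyond the scatter of repeated measurements. Compound 3 `COc1ccc(C(=O)c2ccccc2Cl)cc1OCC(=O)OC[C@@H]1C=C[C@H](n2cc(C)c(=O)[nH]c2=O)O1` has not yet been measured. It differs from compound 2 in one place: 2-chlorophenyl in place of 4-fluorophenyl on a carbonyl carbon. The rest of the molecule, from the shared core to the ring that carries the carbonyl, is unchanged; only the halogen-bearing ring on the carbonyl carbon is exchanged. Among the compounds with values here, no pair of measured compounds shows the effect of such an exchange, so the measured numbers give no direction for it. A step from compound 2 to compound 3 of no more than the usual scatter is expected, in either direction. Compound 3 is estimated to give about 30000 nM in this assay, with a likely range from 8000 nM to 100000 nM. The step this implies, a 1.3-fold lower number from compound 2 to compound 3 (0.13 log units; within the scatter), is expected to stay within the scatter.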

Compound 3, half-maximal inhibitory concentration: 40600 nM
Estimate against measurement, compound 3: 1.4-fold (0.13 log units) below, and the stated range covers the measured number.
By their numbers in this assay, from the lowest: compound 1; then compounds 2 and 3 (each within the scatter of the next).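

In this assay, within the data shown here, putting 2-chlorophenyl in place of 4-fluorophenyl on a carbonyl carbon gives a 1.0-fold higher number from compound 2 to compound 3 (0.00 log units; within the scatter), the first measured look at an exchange at this position, and the read-out does not tell the two rings apart. Both groups have the same count of heavy atoms and are six-membered aromatic rings of carbon only, yet the exchange alters both which halogen is present and where it sits on the ring. These two alterations come together in a single step, so this pair cannot show what either would do alone, and nothing measured here offers an explanation for the match.

Still open, on these data alone, is whether this carbonyl carbon would accept very different groups without a clear step, such as an unsubstituted phenyl or a phenyl ring carrying an amine or a carboxylic acid. Also open, as far as these compounds go, is whether the same exchange would read alike in a compound with a longer chain linking this part of the molecule to the shared core, as in compound 1.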